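Thiophen-3-yl for thiophen-2-yl on a nucleoside core

This account rests on a few compounds, and the source may have more. Where it says the series, first, only, none or still open, it means among the compounds named here.

Compound 1 `Cc1ncnc2c1c(-c1cccs1)cn2[C@@H]1O[C@H](CO)[C@@H](O)[C@H]1O`: > 20000 nM
Compound 2 `CNc1ncnc2c1c(-c1cccs1)cn2[C@@H]1O[C@H](CO)[C@@H](O)[C@H]1O`: > 20000 nM
Compound 3 `Cc1nc(N)c2c(-c3ccsc3)cn([C@@H]3O[C@H](CO)[C@@H](O)[C@H]3O)c2n1`: > 20000 nM

In a functional assay on CEM-DNR-bulk cells (Homo sapiens), read by MTT assay, with a stated time of 72 h (on this read-out lower numbers stand for stronger inhibition and higher numbers for weaker inhibition), compound 1 gives > 20000 nM, which is a limit of the assay and not a number. Compound 2 gives > 20000 nM in this assay, also a limit. Compound 3 gives > 20000 nM in this assay, again a limit. Thus compound 1 stands where all three measured values sit: the limit of > 20000 nM in this assay, at which 3 of the 3 values shown sit. Within the data shown here, the one measured step, a step that the two limits leave unreadable from compound 1 to compound 2, is unreadable for that reason. Compound 4 `Cc1ncnc2c1c(-c1ccsc1)cn2[C@@H]1O[C@H](CO)[C@@H](O)[C@H]1O` differs from compound 1 by thiophen-3-yl in place of thiophen-2-yl on an aromatic carbon. No readable step bears on this change, and compound 3, which also carries thiophen-3-yl, sits at the same limit. No movement beyond the scatter is expected, so the step that the limit leaves unreadable from compound 1 to compound 4 is estimated as essentially nil. Compound 4 is therefore expected to give about 30000 nM, within 10000 nM to 100000 nM, most likely reported as a limit.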

Compound 4, half-maximal inhibitory concentration: 8560 nM
Beside the measured number, compound 4's estimate is 3.5-fold (0.54 log units) above it; the measured number lies below the stated range.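

Moving the attachment point of the thiophene is enough to bring a readable number in this assay: thiophen-3-yl in place of thiophen-2-yl gives an at least 2.3-fold lower number from compound 1 to compound 4 (0.36 log units; beyond the scatter). Compound 4 thus shows that this aromatic carbon responds to a change between two groups with the same atoms, something no earlier compound could show, and it alone among those shown escapes the limit: the limit of > 20000 nM in this assay, at which 3 of the 4 values shown sit. Compound 3, which also carries thiophen-3-yl, gives > 20000 nM, a limit, so the gain does not hold for every compound with this group.

The compounds shown leave open whether furan-3-yl or phenyl at this carbon would also give a readable number.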